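The compounds below may be only part of what the source reports. "The series", "measured", "known", "first", "only" and "open" are said of these compounds alone.

Measured so far:
- Compound 1 `CC(=O)Nc1nc2ccc(-c3cn([C@@H]4CN[C@H](C(=O)Nc5ccc(Cl)c(C(F)(F)F)c5)C4)nn3)nc2s1`: 10000 nM
- Compound 2 `Nc1nc2ccc(-c3cn([C@@H]4CN[C@H](C(=O)Nc5ccc(F)c(F)c5)C4)nn3)nc2s1`: 33200 nM

In a functional assay on K562 cells (Homo sapiens) for inhibition, read by MTT assay, with a stated time of 48 h (on this read-out higher numbers stand for weaker inhibition and lower numbers for stronger inhibition), compound 2 gives 33200 nM, the higher of the two numbers and so the weaker inhibition. Compound 1 gives 10000 nM, and the gap between the two numbers lies beyond the scatter.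

Compound 3 `CC(=O)Nc1nc2ccc(-c3cn([C@@H]4CN[C@H](C(=O)Nc5ccc(F)c(F)c5)C4)nn3)nc2s1` is compound 2 with acetyl in place of hydrogen on a nitrogen on an aromatic ring, which reads as amino to acetamido: acetyl in place of hydrogen on a nitrogen on an aromatic ring. Among the measured compounds shown here, no pair of measured compounds isolates this change, as compound 1 and compound 2 differ in more than one place. Compound 1, which carries the acetamido group, gives 10000 nM, so a small move towards a lower number in this assay is expected. The estimated step of a 1.8-fold lower number from compound 2 to compound 3 (0.27 log units; within the scatter) is therefore expected to be small. Compound 3 is estimated at 18000 nM, with an expected range from 6000 nM to 50000 nM.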

Compound 3, half-maximal inhibitory concentration: 63000 nM
Estimate against measurement, compound 3: 3.5-fold (0.54 log units) below, and the stated range ends below it.
By their numbers in this assay, from the lowest: compound 1; then compounds 2 and 3 (each within the scatter of the next).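

In this assay, among the compounds shown here, the change from amino to acetamido, acetyl in place of hydrogen on a nitrogen on an aromatic ring, gives a 1.9-fold higher number from compound 2 to compound 3 (0.28 log units; within the scatter) and so isolates this change for the first time, showing no step beyond the scatter when the amide carries 3,4-difluorophenyl. For the compounds shown here, with the acetamido group held fixed, 3,4-difluorophenyl in place of 4-chloro-3-(trifluoromethyl)phenyl on an amide-type nitrogen gives a 6.3-fold higher number from compound 1 to compound 3 (0.80 log units; beyond the scatter) and is the one modest step of the two single changes. Nothing measured here accounts for either step.

As far as these compounds go, whether amino to acetamido gives a similar step with 4-chloro-3-(trifluoromethyl)phenyl on the amide remains open. So does what a propionyl group or a methanesulfonyl group on that aromatic amine nitrogen, or a pyridine ring on the amide, would give.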